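A few compounds are considered here, and "the series" means these few. Any claim that something is new, unique, unknown or untested is made for them only; others in the source may bear on it.

Measured so far in an ADME assay for permeability, using PAMPA, at pH 7.4; on this read-out lower numbers stand for lower permeability and higher numbers for higher permeability

Compound 1 (`Cc1cc(NC(=O)Nc2ccc(C(C)(C)C)cc2)c2ccccc2n1`) gives 142 10^-6 cm/s
Compound 2 (`Cc1cc(NC(=O)Nc2ccc(C)c(Cl)c2)c2ccccc2n1`) gives 262 10^-6 cm/s
Compound 3 (`Cc1cc(NC(=O)Nc2ccc(Cl)c(Cl)c2)c2ccccc2n1`) gives 197 10^-6 cm/s

Compound 1 stands within the usual scatter of both compound 2 and compound 3, so these three numbers cannot be told apart. Compound 4 (`CSc1ccc(NC(=O)Nc2cc(C)nc3ccccc23)cc1`) is not yet measured. It carries methylsulfanyl in place of tert-butyl on an aromatic carbon of compound 1 (methylsulfanyl in place of tert-butyl on an aromatic carbon). Among the compounds with values here, no measured step makes this exchange. Within the data shown here, the only single-place step, a 1.3-fold lower number from compound 2 to compound 3 (0.12 log units; within the scatter), exchanges other groups and stays within the scatter, so it offers only indirect support for expecting no real shift in this assay. The expected step, a 1.4-fold higher number from compound 1 to compound 4 (0.15 log units; within the scatter), is estimated to stay within the scatter. Compound 4 is estimated at 200 10^-6 cm/s, with an expected range of 110 10^-6 cm/s to 350 10^-6 cm/s.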

Compound 4, apparent permeability: 473 10^-6 cm/s
Compound 4: middle estimate off by 2.4-fold (0.37 log units), on the low side, and the stated range ends below it.
By their numbers in this assay, from the lowest: compounds 1, 3, 2 and 4 (each within the scatter of the next, the first and the last beyond it).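

In this assay the exchange of tert-butyl for methylsulfanyl on an aromatic carbon gives a 3.3-fold higher number from compound 1 to compound 4 (0.52 log units; beyond the scatter) and so lifts the number beyond the scatter. Within the data shown here, the only earlier step, a 1.3-fold lower number from compound 2 to compound 3 (0.12 log units; within the scatter) for chloro in place of methyl, offered no such shift. This position on the aromatic ring can therefore move the read-out, at least with this pair of groups.

The compounds shown do not separate the entering sulfur from the smaller heavy-atom count, and a methoxy or ethylsulfanyl group here would test that. Nothing measured here gives a cause for this step.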